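Adding one chloro group to compound 2

The compounds below may be only part of what the source reports. "The series", "measured", "known", "first", "only" and "open" are said of these compounds alone.

Compound 1 `COc1cc(/C=C/C(=O)C2=C(/C=C/c3ccc(O)c(OC)c3)NC(=O)NC2c2ccc(C)cc2)ccc1O` gives 100000 nM
Compound 2 `COc1cc(/C=C/C(=O)C2=C(/C=C/c3ccc(O)c(OC)c3)NC(=S)NC2c2ccccc2)ccc1O` gives 100000 nM

In a functional assay on QG-56 cells (Homo sapiens) for cytotoxicity, read by MTT assay, with a stated time of 48 h (on this read-out lower numbers stand for stronger inhibition and higher numbers for weaker inhibition), compound 2 gives 100000 nM and compound 1 gives 100000 nM, so the two cannot be told apart on these numbers. Within the data shown here, these compounds differ in more than one place, so no measured pair shows what a single change does.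

The next compound, compound 3 `COc1cc(/C=C/C(=O)C2=C(/C=C/c3ccc(O)c(OC)c3)NC(=S)NC2c2ccccc2Cl)ccc1O`, matches compound 2 except at one spot. The change is chloro in place of hydrogen on an aromatic carbon and it amounts to chloro in place of hydrogen on an aromatic carbon, ortho to a large group, which turns phenyl to 2-chlorophenyl.

With compound 2 at 100000 nM as the only starting point, there is little to go on, so a modest move toward stronger inhibition, or none beyond the scatter, is the cautious expectation. The expected change is a 1.4-fold lower number from compound 2 to compound 3 (0.15 log units; within the scatter) and it carries wide uncertainty. For compound 3 the estimated value is 70000 nM with 20000 nM to 100000 nM as the expected range.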

Compound 3, half-maximal inhibitory concentration: 50000 nM
Beside the measured number, compound 3's estimate is 1.4-fold (0.15 log units) above it, within the range that was stated.
By their numbers in this assay, from the lowest: compounds 3, 1 and 2 (each within the scatter of the next).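

In this assay, among these compounds, putting chloro in place of hydrogen, which turns phenyl to 2-chlorophenyl, gives a 2.0-fold lower number from compound 2 to compound 3 (0.30 log units; within the scatter), and this is the first pair of compounds here that differ in one place only. Among the compounds shown here, it therefore gives the first direct reading of a single change at this position, on an aromatic carbon ortho to a large group, which the earlier comparison of compound 1 and compound 2 could not give. At this position, this one chloro does not shift the number beyond the ordinary spread of repeated measurements, so the pair shows no clear effect in either direction, and no supporting measurement is available to explain the result.

A single step from one starting compound leaves open whether another group at this position, such as an amine or a carboxylic acid, would move the number beyond the scatter. It also leaves open whether chloro would behave the same way at another carbon of this ring, or on a compound that differs from compound 2 elsewhere in the shared core.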